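Piperidine for methylpiperazine on two aryl cores

This account rests on a few compounds, and the source may have more. Where it says the series, first, only, none or still open, it means among the compounds named here.

Measured compounds:
compound 1 `CN1CCN(c2ccc(Nc3ncc4c(n3)N(C3CCCC3)CC(=O)N4C)cc2)CC1` — 10300 nM
compound 2 `CN1C(=O)CN(C2CCCC2)c2nc(Nc3ccc(N4CCCCC4)cc3)ncc21` — 21200 nM
compound 3 `CN1CCN(c2ccc(Nc3ncc4c(n3)N(C3CCCC3)CC(=O)N4C)nc2)CC1` — 23700 nM

In a functional assay on MDA-MB-231 cells (Homo sapiens) for inhibition, read by MTT assay, with a stated time of 48 h (a lower number here means a stronger inhibitor, a higher number a weaker inhibitor), compound 1 gives 10300 nM, compound 2 gives 21200 nM, and compound 3 gives 23700 nM. Compound 3 and compound 2 lie within the scatter of each other, while compound 3 sits beyond the scatter from compound 1. The difference between the core of compound 1 and the core of compound 3 is not broken down here.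

The change from compound 1 to compound 2 is piperidin-1-yl in place of 4-methylpiperazin-1-yl on an aromatic carbon, and it made a 2.1-fold higher number from compound 1 to compound 2 (0.31 log units; beyond the scatter), a modest step.

Compound 4 `CN1C(=O)CN(C2CCCC2)c2nc(Nc3ccc(N4CCCCC4)cn3)ncc21` has not yet been measured. It differs from compound 3 by piperidin-1-yl in place of 4-methylpiperazin-1-yl on an aromatic carbon. This is the same kind of change as that from compound 1 to compound 2, though not the same: in compound 1 the group sits on a six-membered aromatic ring of carbon only, while in compound 3 it sits on a six-membered aromatic ring with 1 nitrogen, two atoms from the ring nitrogen.

Among the measured compounds shown here, compound 4 is expected to show a 1.9-fold higher number from compound 3 to compound 4 (0.28 log units; within the scatter), placed beside the earlier step, because a 2.1-fold higher number from compound 1 to compound 2 (0.31 log units; beyond the scatter) is the only guide available for this change. On that basis compound 4 is estimated at 45000 nM, between 20000 nM and 100000 nM.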

Compound 4, half-maximal inhibitory concentration: 29300 nM
Beside the measured number, compound 4's estimate is 1.5-fold (0.19 log units) above it; measured number inside the range.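

In this assay the placing of piperidin-1-yl in place of 4-methylpiperazin-1-yl on the second core gives a 1.2-fold higher number from compound 3 to compound 4 (0.09 log units; within the scatter), so on this core the two compounds cannot be told apart, whereas the same change on the first core gave a modest step just beyond the scatter. Set side by side, the two steps differ by no more than repeated measurements of this kind would allow, so nothing here separates the behaviour of the change on one core from its behaviour on the other: the same change on two cores in this assay, a 2.1-fold higher number (0.31 log units; beyond the scatter) from compound 1 to compound 2 and a 1.2-fold higher number (0.09 log units; within the scatter) from compound 3 to compound 4, 1.7-fold (0.22 log units) apart, within the scatter of two such steps. Among the compounds shown here, this shows only that the two steps are compatible, on two pairs of compounds in a single cell assay; it does not show that the change has the same effect on both cores, that it costs anything on the second core, or why the numbers fall as they do.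

The compounds shown leave open whether other groups on the same aromatic carbon, such as morpholin-4-yl, an unsubstituted piperazin-1-yl or an open-chain dimethylamino group, would follow the same course. They also leave open whether the change would carry to a core bearing something other than the cyclopentyl group, such as an isopropyl or a cyclohexyl group.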